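Phenylethenyl Replaces Isopropyl: Expected Shift in Cytotoxicity

The source may hold more compounds than are shown below. What is called first, only, known or untested is meant among the compounds shown, and "the series" means these compounds.

Of the compounds shown here, three built on one shared core have been tested in a toxicity assay on KB cells (Homo sapiens) for cytotoxicity, read by fluorescence, with a stated time of 3 days; on this read-out lower numbers stand for an effect already at smaller amounts and higher numbers for an effect only at larger amounts of compound. Compound 3 `CCCCOC(=O)CNC(=O)[C@H](CSc1ccc([N+](=O)[O-])cc1[N+](=O)[O-])NC(=O)CC[C@H](NC(=O)C(C)C)C(=O)OCCCC` carries an isopropylcarbonyl on an amine nitrogen of that core. In this assay compound 3 gives > 300 uM, which is a limit of the assay and not a number. Compound 1 `CCCCOC(=O)CNC(=O)[C@H](CSc1ccc([N+](=O)[O-])cc1[N+](=O)[O-])NC(=O)CC[C@H](Nc1ccc([N+](=O)[O-])cc1[N+](=O)[O-])C(=O)OCCCC` carries a 2,4-dinitrophenyl on that nitrogen instead. In this assay compound 1 gives > 300 uM, again a limit. The step that the two limits leave unreadable from compound 1 to compound 3 therefore cannot be sized. Among the compounds with values here, compound 2 `CCCCOC(=O)CNC(=O)[C@H](CSc1ccc([N+](=O)[O-])cc1[N+](=O)[O-])NC(=O)CC[C@H](NC(=O)CCc1c[nH]c2ccccc12)C(=O)OCCCC`, with a 2-(1H-indol-3-yl)ethyl on the carbonyl carbon, is the only one with a number: in this assay compound 2 gives 26 uM. The step of an at least 11-fold higher number from compound 2 to compound 3 (1.06 log units; beyond the scatter) shows that exchanging the indole-bearing group for isopropyl pushed the result to the limit (the limit of > 300 uM in this assay, at which 2 of the 3 values shown sit).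

Compound 4 `CCCCOC(=O)CNC(=O)[C@H](CSc1ccc([N+](=O)[O-])cc1[N+](=O)[O-])NC(=O)CC[C@H](NC(=O)/C=C/c1ccccc1)C(=O)OCCCC` has not yet been measured. 2-phenylethenyl in place of isopropyl on a carbonyl carbon An aromatic group thus returns to the carbonyl carbon, much as in compound 2. Because an at least 11-fold higher number from compound 2 to compound 3 (1.06 log units; beyond the scatter) was large when the aromatic group left, its return is expected to bring the number back down. Compound 4 is therefore expected to show the step of an at least 6.0-fold lower number from compound 3 to compound 4 (0.77 log units; beyond the scatter). The estimated value for compound 4 is 50 uM, within a range from 12 uM to 300 uM.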

Compound 4, concentration for half-maximal effect: 34.4 uM
The estimate for compound 4 lay 1.5-fold (0.16 log units) above the measured number; low and high end bracket the measured number.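

In this assay, 2-phenylethenyl in place of isopropyl on the carbonyl carbon gives an at least 8.7-fold lower number from compound 3 to compound 4 (0.94 log units; beyond the scatter), and (2-phenylethenyl)carbonyl in place of 2,4-dinitrophenyl on the amine nitrogen gives an at least 8.7-fold lower number from compound 1 to compound 4 (0.94 log units; beyond the scatter), so a second group at this place now yields a readable number, although compound 1 goes against any simple rule that an aromatic ring on this nitrogen is enough. The indole part is not needed for a number in this range, since 2-phenylethenyl in place of 2-(1H-indol-3-yl)ethyl gives a 1.3-fold higher number from compound 2 to compound 4 (0.12 log units; within the scatter), and these two quite different groups cannot be told apart here. Compound 1 and compound 3 each stand at a limit and not at a number, so the two steps that start from them give only a smallest possible size: the limit of > 300 uM in this assay, at which 2 of the 4 values shown sit.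

The compounds shown leave open whether the double bond of 2-phenylethenyl counts, which a saturated 2-phenylethyl group on the same carbonyl carbon would test, and whether a plain phenyl there would do the same. They also leave open how an amine or a carboxylic acid on the aromatic ring would change the number.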